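The source may report more compounds than this note shows. Statements on the series, on what has been measured and on what is new or still open speak of the compounds shown alone.

Measured so far:
- compound 1, `Fc1ccc(C2=NN(c3nc(-c4ccccc4)cs3)C(c3cccs3)C2)cc1`, 2340 nM
- compound 2, `Fc1ccc(C2=NN(c3nc(-c4ccc(C(F)(F)F)cc4)cs3)C(c3cccs3)C2)cc1`, 1330 nM
- compound 3, `Brc1ccc(C2=NN(c3nc(-c4ccccc4)cs3)C(c3cccs3)C2)cc1`, 6790 nM

All three were run in a functional assay on MCF7 cells (Homo sapiens) for antiproliferative activity, read by MTT assay, with a stated time of 48 h; on this read-out higher numbers stand for weaker inhibition and lower numbers for stronger inhibition. Compound 2 differs from compound 1 by trifluoromethyl in place of hydrogen on an aromatic carbon; the step was a 1.8-fold lower number from compound 1 to compound 2 (0.25 log units; within the scatter), so the two values cannot be ordered with confidence. Compound 3 differs from compound 1 by bromo in place of fluoro on an aromatic carbon, and here the step was a 2.9-fold higher number from compound 1 to compound 3 (0.46 log units; beyond the scatter). Compound 3 therefore gives the highest number of the three in this assay, beyond the scatter against both compound 1 and compound 2.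

Compound 4, `FC(F)(F)c1ccc(-c2csc(N3N=C(c4ccc(Br)cc4)CC3c3cccs3)n2)cc1`, is not yet measured. It differs from compound 3 by trifluoromethyl in place of hydrogen on an aromatic carbon. This is the same change that separates compound 2 from compound 1, made on the core of compound 3 rather than the core of compound 1; the two cores differ by the bromo-for-fluoro exchange described above. The place of the change reads identically in both cases, so it is treated as the same change.

For compound 4 the step is expected to be a 1.7-fold lower number from compound 3 to compound 4 (0.23 log units; within the scatter), resting on the single earlier occurrence of this change, where compound 1 to compound 2 gave a 1.8-fold lower number from compound 1 to compound 2 (0.25 log units; within the scatter). Among the compounds with values here, with only one precedent, and that one within the scatter, the expectation is loose. Compound 4 is estimated at 4000 nM in this assay, between 1800 nM and 9000 nM.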

Compound 4, half-maximal inhibitory concentration: 7810 nM
Beside the measured number, compound 4's estimate is 2.0-fold (0.29 log units) below it, and the stated range covers the measured number.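

In this assay, trifluoromethyl in place of hydrogen on the core of compound 3 gave a 1.2-fold higher number from compound 3 to compound 4 (0.06 log units; within the scatter), and this step does not differ from the earlier one on the core of compound 1: the same change on two cores in this assay, a 1.8-fold lower number (0.25 log units; within the scatter) from compound 1 to compound 2 and a 1.2-fold higher number (0.06 log units; within the scatter) from compound 3 to compound 4, 2.0-fold (0.31 log units) apart, within the scatter of two such steps. The bromo-for-fluoro exchange, now also readable with trifluoromethyl present, gave a 5.9-fold higher number from compound 2 to compound 4 (0.77 log units; beyond the scatter), and it too agrees with its earlier occurrence: the same change on two cores in this assay, a 2.9-fold higher number (0.46 log units; beyond the scatter) from compound 1 to compound 3 and a 5.9-fold higher number (0.77 log units; beyond the scatter) from compound 2 to compound 4, 2.0-fold (0.31 log units) apart, within the scatter of two such steps. Within these four compounds, both changes therefore carry from one core to the other, with the trifluoromethyl step inside the scatter on both cores and the bromo step beyond it on both, but this does not show that trifluoromethyl shifts the read-out at all, nor that the agreement extends past this single pair of cores.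

The compounds shown leave open whether a group other than hydrogen or trifluoromethyl at that place on the phenyl ring, such as a methoxy, a nitrile or an amine, would give a step beyond the scatter. They also leave open whether chloro in place of fluoro or bromo would follow the bromo step, and whether either change would carry over to a core that differs in some other place.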